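Dimethoxyphenyl replacing phenyl: expected lipophilicity step

This account rests on a few compounds, and the source may have more. Where it says the series, first, only, none or still open, it means among the compounds named here.

Compound 1 `O=C(CN1C(=O)c2ccccc2C1=O)NN1C(=O)CSC1c1ccccc1` gives 2.23 in a physicochemical assay for lipophilicity, in phosphate buffer, measured as octanol-water partition, with a stated time of 24 h (a higher number here means a more lipophilic compound, a lower number a more polar compound), and stands alongside compound 2 `O=C(CN1C(=O)c2ccccc2C1=O)NN1C(=O)CSC1c1ccc(O)cc1`, which gives 2.4 in this assay. Within the data shown here, the one measured step between them, a number 0.17 log units higher from compound 1 to compound 2 (within the scatter), stays within the scatter. Compound 3 `COc1ccc(C2SCC(=O)N2NC(=O)CN2C(=O)c3ccccc3C2=O)cc1OC` carries 3,4-dimethoxyphenyl in place of phenyl on a saturated ring carbon. Among the measured compounds shown here, no measured step covers two methoxy groups on that ring, and the hydroxy step offers only a loose guide, so the expected step in this assay is small, at most a slight rise, as a number 0.12 log units higher from compound 1 to compound 3 (within the scatter). Compound 3 is therefore estimated at 2.35, between 1.95 and 2.75.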

Compound 3, partition coefficient: 2.78
Estimate against measurement, compound 3: 0.43 log units below, outside the stated range (above it).
By their numbers in this assay, from the lowest: compounds 1 and 2 (each within the scatter of the next); then compound 3.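

At this saturated ring carbon, a change of the aromatic group can move the number beyond the scatter: a number 0.55 log units higher from compound 1 to compound 3 (beyond the scatter) in this assay for 3,4-dimethoxyphenyl in place of phenyl, unlike the hydroxy step. The same group in place of 4-hydroxyphenyl also clears the scatter, with a number 0.38 log units higher from compound 2 to compound 3 (beyond the scatter) in this comparison. No measurement offered here accounts for either step.

The compounds shown leave open whether one methoxy group alone would give a step of this size. As far as these compounds go, how an amine or a carboxylic acid on that aromatic ring would move this number also remains open.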